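The source may hold more compounds than are shown below. What is called first, only, known or untested is meant among the compounds shown, and "the series" means these compounds.

Measured so far in a physicochemical assay for acid dissociation:

Compound 1, `COc1ccc(-c2ccc3c(NCCCNCc4cccc(OC)c4O)ccnc3c2)cc1`: compound 1 gives 9.47
Compound 2, `COc1cccc(CNCCCNc2ccnc3cc(Cc4cccc(C(F)(F)F)c4)ccc23)c1O`: compound 2 gives 9.47
Compound 3, `COc1ccc(-c2ccc3c(NCCCNCc4cc(F)ccc4OC)ccnc3c2)cc1`: compound 3 gives 9.47

Two one-place changes link these compounds. From compound 1 to compound 2 the change is 3-(trifluoromethyl)benzyl in place of 4-methoxyphenyl on an aromatic carbon, and the outcome in this assay is no change at the digits printed from compound 1 to compound 2 (within the scatter). The cores of compound 1 and compound 3 differ by 5-fluoro-2-methoxyphenyl in place of 2-hydroxy-3-methoxyphenyl on a saturated chain carbon bound to an amine nitrogen, and this gives no change at the digits printed from compound 1 to compound 3 (within the scatter). So neither change moved the acid dissociation constant.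

Compound 4, `COc1ccc(F)cc1CNCCCNc1ccnc2cc(Cc3cccc(C(F)(F)F)c3)ccc12`, has not yet been measured. It is reached from compound 3 by 3-(trifluoromethyl)benzyl in place of 4-methoxyphenyl on an aromatic carbon. Going by the values given here, this is the same change as the one from compound 1 to compound 2, and it sits in the same place, described in the same words, on a core that differs only as just described. The step from compound 3 to compound 4 is therefore expected to be no change at the digits printed from compound 3 to compound 4 (within the scatter), because no change at the digits printed from compound 1 to compound 2 (within the scatter) on the closely related core of compound 1 showed no change. The estimate for compound 4 in this assay is 9.47, between 9.2 and 9.75.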

Compound 4, acid dissociation constant: 9.47
For compound 4 middle estimate and measured number coincide at the digits printed, within the range that was stated.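

In this assay the swap to 3-(trifluoromethyl)benzyl from 4-methoxyphenyl on an aromatic carbon gives no change at the digits printed from compound 3 to compound 4 (within the scatter) and so matches the outcome of the same swap on the core of compound 1. The swap to 5-fluoro-2-methoxyphenyl from 2-hydroxy-3-methoxyphenyl likewise gives no change at the digits printed from compound 2 to compound 4 (within the scatter) and so each change carries from one core to the other with the same outcome across these four compounds. This is a single result on one pair of cores and in one read-out, not a rule for the whole series, and no measurement is given that could explain it.

The compounds shown leave open how the number responds when the group on the aromatic carbon carries an amine or a carboxylic acid. They also leave open whether the outcome holds with a longer chain in place of the saturated chain that links the two amine nitrogens.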